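A few compounds are considered here, and "the series" means these few. Any claim that something is new, unique, unknown or untested is made for them only; others in the source may bear on it.

Compound 1 `COc1ccc([C@H]2CC(=O)N(c3ccncc3)C2)cc1OC1CCCC1` gives in a functional assay on HEK293 cells (Homo sapiens) for cytotoxicity (a higher number here means that more compound is tolerated, a lower number that less compound is tolerated), the value > 10000 nM, which is a limit of the assay.
Compound 2 `COc1ccc([C@H]2CC(=O)N(c3cccc(NCc4ccoc4)c3)C2)cc1OC1CCCC1` gives in this assay the value > 10000 nM, again a limit rather than a number.

Compound 2 therefore stands at the limit of this assay, and so does the only other measured compound; no number is known for either, so no step between measured compounds can be read, and nothing separates compound 2 from compound 1 on the shown values, as the limit of > 10000 nM in this assay, at which 2 of the 2 values shown sit, states. Compound 3 `COc1ccc([C@H]2CC(=O)N(c3cccc(NS(=O)(=O)c4cccc(Br)c4)c3)C2)cc1OC1CCCC1` is not yet measured in this assay. It differs from compound 2 in one place: (3-bromophenyl)sulfonyl in place of (furan-3-yl)methyl on a nitrogen on an aromatic ring. Among the measured compounds shown here, with both known values sitting at the same limit, there is no measured step on which to base a direction, and no change beyond the usual scatter is expected for this assay from compound 2 to compound 3. Compound 3 is therefore expected to sit at or near the same limit in this assay, with an estimated value of 10000 nM (range 3000 nM to 30000 nM), which amounts to an expected step of a number no higher from compound 2 to compound 3 (the limit leaves the size open).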

Compound 3, half-maximal cytotoxic concentration: > 10000 nM
Compound 3 was reported as a limit; the forecaster's own chance of this, stated with the estimate: 70%; the middle value lies on the limit itself.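

No step can be read between compound 2 and compound 3, as both stand at the same limit of the assay: the limit of > 10000 nM in this assay, at which 3 of the 3 values shown sit.

The compounds shown leave open what number lies behind the limit for any of them, and so whether (3-bromophenyl)sulfonyl in place of (furan-3-yl)methyl changes anything in this assay.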